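Urea and Thiourea Analogues Tested on Rat Aorta

A few compounds are considered here, and "the series" means these few. Any claim that something is new, unique, unknown or untested is made for them only; others in the source may bear on it.

Compound 1, `CC1(C)CN(NC(=S)Nc2cccc(Cl)c2)c2cc(Cl)ccc2O1`, in a functional assay on thoracic aorta (Rattus norvegicus); on this read-out higher numbers stand for an effect only at larger amounts of compound and lower numbers for an effect already at smaller amounts: > 30000 nM, a limit of the assay.
Compound 2, `CC1(C)CN(NC(=S)Nc2ccc(Cl)cc2)c2cc(Cl)ccc2O1`, in this assay: > 30000 nM, also a limit.
Compound 3, `CC1(C)CN(NC(=O)Nc2cccc(Cl)c2)c2cc(Cl)ccc2O1`, in this assay: 9900 nM.

Compound 2 differs from compound 1 by 4-chlorophenyl in place of 3-chlorophenyl on an amide-type nitrogen. The step that the two limits leave unreadable from compound 1 to compound 2 cannot be read because the limit of > 30000 nM in this assay, at which 2 of the 3 values shown sit, hides both values. The difference between the cores of compound 1 and compound 3 is not broken down here. Compound 4, `CC1(C)CN(NC(=O)Nc2ccc(Cl)cc2)c2cc(Cl)ccc2O1`, not yet measured, differs from compound 3 by 4-chlorophenyl in place of 3-chlorophenyl on an amide-type nitrogen, the same kind of change as from compound 1 to compound 2, but the other neighbour of the nitrogen is a carbonyl carbon here and a thiocarbonyl carbon there. Since the earlier step is unreadable, a small step is expected, a 1.4-fold higher number from compound 3 to compound 4 (0.15 log units; within the scatter). Compound 4 is thus estimated at 14000 nM, between 5000 nM and 40000 nM.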

Compound 4, half-maximal effective concentration: 13300 nM
For compound 4 the middle estimate is 1.1-fold (0.02 log units) above the measured one; the measured number falls inside the stated range.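

On the core of compound 3, putting 4-chlorophenyl in place of 3-chlorophenyl gives a 1.3-fold higher number from compound 3 to compound 4 (0.13 log units; within the scatter) in this assay, so on this core the two groups cannot be told apart. Within the data shown here, the same change on the core of compound 1 cannot be read: the limit of > 30000 nM in this assay, at which 2 of the 4 values shown sit. With only one readable step, these compounds do not show whether the change behaves the same way on both cores.

Going by these compounds, it also remains open what an amine or a carboxylic acid would do in place of the chlorine on the phenyl ring. Whether a longer chain in place of the chlorophenyl group would shift the number in this assay is equally unknown.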